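The compounds below may be only part of what the source reports. "The series", "measured", "known", "first", "only" and "open" are said of these compounds alone.

Measured so far:
- compound 1, `COc1cc(/C=C/c2ccc(S(N)(=O)=O)cc2)cc(OC)c1`: 12300 nM
- compound 2, `COc1cccc(/C=C/c2ccc(S(N)(=O)=O)cc2)c1`: 2910 nM
- compound 3, `NS(=O)(=O)c1ccc(/C=C/c2ccc(F)cc2)cc1`: 7970 nM

In a functional assay on NCI-H226 cells (Homo sapiens) for inhibition (a lower number here means a stronger inhibitor of growth, a higher number a weaker inhibitor of growth), compound 2 stands lowest of the three numbers, so it is the strongest inhibitor of growth among the three. The nearest to compound 2 is compound 3, whose value of 7970 nM lies beyond the scatter from that of compound 2. Among the measured compounds shown here, the furthest is compound 1, and the single measured step, a 4.2-fold lower number from compound 1 to compound 2 (0.63 log units; beyond the scatter), describes that gap.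

Compound 4, `NS(=O)(=O)c1ccc(/C=C/c2cccc(O)c2)cc1`, is not yet measured. It differs from compound 2 in one place: hydrogen in place of methyl on an oxygen on an aromatic ring. For the measured compounds named here, the only measured step, from compound 1 to compound 2, concerns a methoxy group that disappears from an aromatic carbon, which is a different change from the methyl that leaves an oxygen on an aromatic ring here. Going by the values given here, it therefore gives no direct guide, and the three compounds carry no example of a hydroxy group at all. Without such an example the expectation for compound 4 in this assay is kept close to the value of compound 2, with a wide range. The step expected from compound 2 to compound 4 is a 1.4-fold higher number from compound 2 to compound 4 (0.14 log units; within the scatter), which lies within the scatter. For compound 4 the estimated value is 4000 nM, with a range from 1300 nM to 12000 nM.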

Compound 4, concentration for 50% growth inhibition: 25800 nM
Beside the measured number, compound 4's estimate is 6.5-fold (0.81 log units) below it; measured number above the stated range.
By their numbers in this assay, from the lowest: compound 2; then compounds 3 and 1 (each within the scatter of the next); then compound 4.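

In this assay the methyl on this oxygen proves to matter, with an 8.9-fold higher number from compound 2 to compound 4 (0.95 log units; beyond the scatter) when methoxy becomes hydroxy, a step beyond the scatter even though only a single carbon leaves. Among the compounds shown here, the one earlier step, a 4.2-fold lower number from compound 1 to compound 2 (0.63 log units; beyond the scatter) where a whole methoxy group gives way to hydrogen, had moved the number in the opposite direction, so changes of methoxy groups on this ring do not all act alike, and a hydroxy group does not stand in for the methoxy of compound 2 here. No measurement in hand accounts for this rise in the number.

The compounds shown leave open what happens when the methyl on this oxygen gives way to something larger, such as an ethyl group or a longer chain, and whether any such group would give a lower number than compound 2 does. They also leave open how an amine or a carboxylic acid would compare with hydroxy on the same aromatic carbon, and whether the methoxy to hydroxy change would have a similar size in compound 1, which carries two methoxy groups.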